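The compounds below may be only part of what the source reports. "The series", "measured", "known", "first", "only" and "open" are said of these compounds alone.

Three compounds share one core and differ only in the group carried on an aromatic nitrogen of the five-membered ring. In a functional assay on HepG2 cells (Homo sapiens) for antiproliferative activity, read by MTT assay, with a stated time of 48 h (a lower number here means a stronger inhibitor, a higher number a weaker inhibitor), compound 1 `N#CC1=C(N)Oc2c(c3nc4ccccc4nc3c3ccccc23)C12C(=O)N(Cc1cnnn1-c1ccc([N+](=O)[O-])cc1)c1ccccc12` gives > 50000 nM, which is a limit of the assay and not a number. In this assay compound 2 `N#CC1=C(N)Oc2c(c3nc4ccccc4nc3c3ccccc23)C12C(=O)N(Cc1cnnn1-c1ccc(N)cc1)c1ccccc12` gives > 50000 nM, again a limit rather than a number. For the measured compounds named here, compound 3 `N#CC1=C(N)Oc2c(c3nc4ccccc4nc3c3ccccc23)C12C(=O)N(Cc1cnnn1-c1ccc(S(N)(=O)=O)cc1)c1ccccc12` is the only one with a measured number: in this assay compound 3 gives 42200 nM, close to the limit of > 50000 nM in this assay, at which 2 of the 3 values shown sit. The two readable steps, an at least 1.1-fold lower number from compound 1 to compound 3 (0.07 log units; that floor lies within the scatter) and an at least 1.1-fold lower number from compound 2 to compound 3 (0.07 log units; that floor lies within the scatter), have floors that lie within the scatter, and there is a step that the two limits leave unreadable from compound 1 to compound 2. Compound 4 `Cc1ccc(-n2nncc2CN2C(=O)C3(C(C#N)=C(N)Oc4c3c3nc5ccccc5nc3c3ccccc43)c3ccccc32)cc1Cl` carries 3-chloro-4-methylphenyl in place of 4-sulfamoylphenyl on an aromatic nitrogen. Going by the values given here, no measured step exchanges the group for one of this kind, so the expectation rests only on the fact that every change so far left the number near or beyond the limit; the estimated step is a 1.1-fold higher number from compound 3 to compound 4 (0.03 log units; within the scatter), none beyond the scatter. The estimate for compound 4 is therefore 45000 nM, within 15000 nM to 150000 nM, with a real chance that only a limit is reported.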

Compound 4, half-maximal inhibitory concentration: > 50000 nM
Compound 4: no number, only a limit; the forecaster's own chance of this, stated with the estimate: 55%; middle value at least 1.1-fold (0.04 log units) from the limit.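

Compound 4 has a different kind of phenyl group on this aromatic nitrogen, one with no hydrogen-bond donors or acceptors, and in this assay compound 4 gives > 50000 nM, a limit of the assay and not a number. Exchanging 4-sulfamoylphenyl for 3-chloro-4-methylphenyl gives an at least 1.1-fold higher number from compound 3 to compound 4 (0.07 log units; that floor lies within the scatter), and the other two steps ending at compound 4 cannot be read. Four substituted phenyl groups at this position have now produced no clear move away from the limit, and compound 3 alone gives a number: the limit of > 50000 nM in this assay, at which 3 of the 4 values shown sit.

The compounds shown leave open whether a group other than a substituted phenyl, such as a benzyl or a simple alkyl amine chain, could bring the number well below the limit. They also leave open what the shared core gives in this assay with a different group on the oxindole-free side of this position.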